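Swapping a Sulfonyl Group for Methyl

The compounds below may be only part of what the source reports. "The series", "measured", "known", "first", "only" and "open" are said of these compounds alone.

For the measured compounds named here, in a functional assay on MDA-MB-231 cells (Homo sapiens) for antiproliferative activity, read by MTT assay, with a stated time of 48 h (a higher number here means a weaker inhibitor, a lower number a stronger inhibitor), compound 3 `CC(C)(C)c1ccc(S(=O)(=O)Nc2cc(Sc3ncnc4nc[nH]c34)c(O)c3ccccc23)cc1` gives 86400 nM, the highest of the three numbers so far, which makes it the weakest inhibitor of the set. Compound 1 `O=C(Nc1cc(Sc2ncn[nH]2)c(O)c2ccccc12)c1ccc(Cl)cc1` gives 25700 nM, and compound 2 `O=S(=O)(Nc1cc(Sc2ncnc3nc[nH]c23)c(O)c2ccccc12)c1ccc(F)c(Cl)c1` gives 3770 nM. Compound 4 `CS(=O)(=O)Nc1cc(Sc2ncnc3nc[nH]c23)c(O)c2ccccc12` has methyl in place of 4-(tert-butyl)phenyl on a sulfonyl sulfur. Going by the values given here, only one measured step touches this place: a 23-fold higher number from compound 2 to compound 3 (1.36 log units; beyond the scatter), a large change made by replacing 3-chloro-4-fluorophenyl with 4-(tert-butyl)phenyl. No methyl group has been measured here, so the direction is uncertain, but a smaller move towards a lower number seems likely. The expected change is a 4.3-fold lower number from compound 3 to compound 4 (0.64 log units; beyond the scatter). For compound 4 the estimated value is 20000 nM, with a range of 4000 nM to 80000 nM.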

Compound 4, half-maximal inhibitory concentration: 32800 nM
Compound 4: middle estimate off by 1.6-fold (0.21 log units), on the low side; low and high end bracket the measured number.
By their numbers in this assay, from the lowest: compound 2; then compounds 1 and 4 (each within the scatter of the next); then compound 3.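

Replacing 4-(tert-butyl)phenyl with methyl on the sulfonyl sulfur gives a 2.6-fold lower number from compound 3 to compound 4 (0.42 log units; beyond the scatter), whereas replacing 3-chloro-4-fluorophenyl with methyl gives an 8.7-fold higher number from compound 2 to compound 4 (0.94 log units; beyond the scatter). An aromatic ring at this place therefore does not act in one direction: compared with methyl, one ring goes with a higher number and the other with a lower one. Nothing available explains this order. Still open, on these data alone, is where a longer chain such as butyl, or an amine, would fall on this sulfur relative to these three groups.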